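Chain end exchange from compound 3 to compound 4

The source may report more compounds than this note shows. Statements on the series, on what has been measured and on what is new or still open speak of the compounds shown alone.

Values in a functional assay (trachea) with Cavia porcellus as the target; on this read-out lower numbers stand for an effect already at smaller amounts and higher numbers for an effect only at larger amounts of compound:
- compound 1 `CCCn1c(=O)n(C)c(=O)c2[nH]cnc21`: 1600 nM
- compound 2 `CCCn1c(=O)n(C)c(=O)c2c1ncn2CC#N`: 35300 nM
- compound 3 `CCCn1c(=O)n(C)c(=O)c2c1ncn2CCCN(C)C`: > 100000 nM (a limit)
- compound 4 `CCCn1c(=O)n(C)c(=O)c2c1ncn2CCOCC`: not yet measured

Compound 3 gives only a limit, > 100000 nM, and no number.

The change to compound 4 is ethoxy in place of (dimethylamino)methyl on a saturated chain carbon, two bonds along the chain from an aromatic nitrogen.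

Both chains on that nitrogen gave large steps: a 22-fold higher number from compound 1 to compound 2 (1.34 log units; beyond the scatter) and an at least 62-fold higher number from compound 1 to compound 3 (1.79 log units; beyond the scatter). Changing the chain end alone gave an at least 2.8-fold higher number from compound 2 to compound 3 (0.45 log units; beyond the scatter). Compound 4 keeps a chain there, so a number well above that of compound 1 at 1600 nM is expected. The new chain end is expected to give a modest step down in this assay, towards compound 2 at 35300 nM. The expected step is an at least 3.3-fold lower number from compound 3 to compound 4 (0.52 log units; beyond the scatter). Compound 4 is estimated at 30000 nM, with an expected range of 9000 nM to 90000 nM.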

Compound 4, half-maximal effective concentration: 4600 nM
The estimate for compound 4 lay 6.5-fold (0.81 log units) above the measured number; measured number below the stated range.
By their numbers in this assay, from the lowest: compound 1; then compound 4; then compound 2. At a limit, above all of these: compound 3.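

In this assay, the 2-ethoxyethyl chain shows that substitution on this aromatic nitrogen need not cost much, with a 2.9-fold higher number from compound 1 to compound 4 (0.46 log units; beyond the scatter). The end of the chain sets the size of the loss among these compounds, with a 7.7-fold lower number from compound 2 to compound 4 (0.89 log units; beyond the scatter) and an at least 21-fold lower number from compound 3 to compound 4 (1.33 log units; beyond the scatter). The second of these steps starts from compound 3, whose value is only a limit: the limit of > 100000 nM in this assay, at which 1 of the 4 values shown sits.

The compounds shown do not separate the ether oxygen from the chain length. A pentyl chain or a 2-methoxyethyl chain on the same nitrogen would bear on that question.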